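The source may hold more compounds than are shown below. What is called first, only, known or untested is meant among the compounds shown, and "the series" means these compounds.

Of the compounds shown here, three built on one shared core have been measured in a physicochemical assay for lipophilicity, using the shake flask method, in phosphate buffer, measured as octanol-water partition, with a stated time of 85 min, at pH 7.4; on this read-out lower numbers stand for lower lipophilicity and higher numbers for higher lipophilicity. Compound 1 `COc1ccc(-c2cn3ccnc3c(-c3ccc4ncn(C5CCCCC5)c4c3)n2)cc1` gives 1.41, the lowest of the three numbers. Compound 2 `O=Cc1ccc(-c2cn3ccnc3c(-c3ccc4ncn(C5CCCCC5)c4c3)n2)cc1` gives 1.5, and compound 3 `Cc1cccc(-c2cn3ccnc3c(-c3ccc4ncn(C5CCCCC5)c4c3)n2)c1` gives 1.87. The step of a number 0.09 log units higher from compound 1 to compound 2 (within the scatter) stays within the scatter, whereas a number 0.46 log units higher from compound 1 to compound 3 (beyond the scatter) and a number 0.37 log units higher from compound 2 to compound 3 (beyond the scatter) lie beyond it. Compound 4 `CC(=O)c1ccc(-c2cn3ccnc3c(-c3ccc4ncn(C5CCCCC5)c4c3)n2)cc1` differs from compound 1 in one place: acetyl in place of methoxy on an aromatic carbon. Going by the values given here, the closest precedent is a number 0.09 log units higher from compound 1 to compound 2 (within the scatter), where formyl replaced methoxy on an aromatic carbon, and acetyl is a close cousin of formyl. A step for compound 4 no larger than the scatter is therefore expected, a number 0.14 log units higher from compound 1 to compound 4 (within the scatter). Compound 4 is expected to give 1.55, with a likely range from 1.25 to 1.85.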

Compound 4, partition coefficient: 2.06
Compound 4: middle estimate off by 0.51 log units, on the low side; measured number above the stated range.
By their numbers in this assay, from the lowest: compounds 1 and 2 (each within the scatter of the next); then compounds 3 and 4 (each within the scatter of the next).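

On this aromatic carbon, formyl and acetyl are not interchangeable: methyl in place of hydrogen on the carbonyl carbon gives a number 0.56 log units higher from compound 2 to compound 4 (beyond the scatter) in this assay. Acetyl in place of methoxy gives a number 0.65 log units higher from compound 1 to compound 4 (beyond the scatter), so swapping out methoxy can shift this read-out beyond the scatter, which formyl did not show. Against the 3-methylphenyl group, 4-acetylphenyl gives a number 0.19 log units higher from compound 3 to compound 4 (within the scatter). Nothing available explains why one added methyl matters this much. Going by these compounds, whether a longer chain on the carbonyl or an amide at this place would give a similar step remains open.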